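This account rests on a few compounds, and the source may have more. Where it says the series, first, only, none or still open, it means among the compounds named here.

Measured so far:
compound 1 `CCN1CCN(C(=S)SCC(=O)N(Cc2ccc(OC)cc2)c2cc(OC)c(OC)c(OC)c2)CC1`, 9890 nM
compound 2 `COc1ccc(CN(C(=O)CSC(=S)N2CCN(C(C)=O)CC2)c2cc(OC)c(OC)c(OC)c2)cc1`, 480 nM
compound 3 `CCN1CCN(CC(=O)N(Cc2ccc(OC)cc2)c2cc(OC)c(OC)c(OC)c2)CC1`, only a limit

In a functional assay on MGC-803 cells (Homo sapiens) for inhibition, read by CCK-8 assay, with a stated time of 48 h (on this read-out lower numbers stand for stronger inhibition and higher numbers for weaker inhibition), compound 1 gives 9890 nM and compound 2 gives 480 nM. Compound 3 reaches only a limit of this assay, > 20000 nM. That limit is the limit of > 20000 nM in this assay, at which 1 of the 3 values shown sits.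

The step of a 21-fold lower number from compound 1 to compound 2 (1.31 log units; beyond the scatter) goes with the change (acetyl in place of ethyl on an amine nitrogen in a ring). The cores of compound 1 and compound 3 differ as a group of 8 heavy atoms (6 carbon, 2 nitrogen; one six-membered non-aromatic ring with 2 hetero atoms) in place of a group of 11 heavy atoms (7 carbon, 2 nitrogen, 2 sulfur; one six-membered non-aromatic ring with 2 hetero atoms), on a saturated chain carbon bound to a carbonyl carbon, with the step of an at least 2.0-fold higher number from compound 1 to compound 3 (0.30 log units; that floor lies within the scatter); the further step is an at least 41-fold higher number from compound 2 to compound 3 (1.61 log units; beyond the scatter).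

Compound 4 `COc1ccc(CN(C(=O)CN2CCN(C(C)=O)CC2)c2cc(OC)c(OC)c(OC)c2)cc1` is not yet measured in this assay. It differs from compound 3 by acetyl in place of ethyl on an amine nitrogen in a ring, the same change as from compound 1 to compound 2, and the place description agrees word for word.

If the change carries over to the core of compound 3, a step of about an at least 4.0-fold lower number from compound 3 to compound 4 (0.60 log units; beyond the scatter) is expected, set smaller than a 21-fold lower number from compound 1 to compound 2 (1.31 log units; beyond the scatter) since the starting point of compound 3 is a limit and not a number. Compound 4 is therefore expected near 5000 nM, estimated between 1000 nM and 25000 nM.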

Compound 4, half-maximal inhibitory concentration: 12800 nM
The estimate for compound 4 lay 2.6-fold (0.41 log units) below the measured number, within the range that was stated.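

In this assay the step for acetyl in place of ethyl on the core lacking the two sulfur atoms is an at least 1.5-fold lower number from compound 3 to compound 4 (0.19 log units; that floor lies within the scatter), so a gain of the size seen on the core of compound 1 is neither shown nor excluded: the same change on two cores in this assay, a 21-fold lower number (1.31 log units; beyond the scatter) from compound 1 to compound 2 and an at least 1.5-fold lower number (0.19 log units; that floor lies within the scatter) from compound 3 to compound 4; the limit leaves it open whether they differ.
Compound 3 gives only a limit and not a number: the limit of > 20000 nM in this assay, at which 1 of the 4 values shown sits.
With 4-acetylpiperazin-1-yl held fixed, the group with the two sulfur atoms gives way to the shorter link in a 27-fold higher number from compound 2 to compound 4 (1.43 log units; beyond the scatter), while a 1.3-fold higher number from compound 1 to compound 4 (0.11 log units; within the scatter), so in these four compounds the large step for acetyl appears only where that sulfur-bearing group is present, and one pair cannot show that this holds more widely.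

A true number for compound 3 would be needed to size the step on its core. Among the compounds shown here, also open is whether other groups on that ring nitrogen, such as propionyl or methanesulfonyl, follow acetyl, and whether a link with oxygen in place of the sulfur atoms behaves like the one in compound 2.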